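Swapping dimethylamino for 4-methylpiperazin-1-yl in the anilide series

A few compounds are considered here, and "the series" means these few. Any claim that something is new, unique, unknown or untested is made for them only; others in the source may bear on it.

Measured in an ADME assay on BaF3 cells (Mus musculus) for antiproliferative activity, read by CCK-8 assay, with a stated time of 72 h; a higher number here means a weaker inhibitor of growth, a lower number a stronger inhibitor of growth:
Compound 1 `O=C(CCSc1ccc2c(/C=C/c3ccccn3)n[nH]c2c1)Nc1cccc(Cl)c1`: 9350 nM
Compound 2 `CN(C)c1cccc(NC(=O)CCSc2ccc3c(/C=C/c4ccccn4)n[nH]c3c2)c1`: > 10000 nM (a limit of the assay)

Compound 2 has no exact number, and its > 10000 nM is a limit. This is the limit of > 10000 nM in this assay, at which 1 of the 2 values shown sits.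

The next compound is compound 3 `CN1CCN(c2cccc(NC(=O)CCSc3ccc4c(/C=C/c5ccccn5)n[nH]c4c3)c2)CC1`, which carries 4-methylpiperazin-1-yl in place of dimethylamino on an aromatic carbon, meta to a large group: 4-methylpiperazin-1-yl in place of dimethylamino on an aromatic carbon. For the measured compounds named here, no measured step covers this exchange directly. Going by the values given here, the nearest guide is the only measured step, an at least 1.0-fold higher number from compound 1 to compound 2 (0.02 log units; that floor lies within the scatter), which replaced chloro with dimethylamino on an aromatic carbon. As far as these compounds go, since that figure is only a floor, the true size of the step remains open.

With so little evidence, no step beyond the scatter is expected in this assay, and no direction can be favoured. The expected step is an at least 1.2-fold lower number from compound 2 to compound 3 (0.09 log units; that floor lies within the scatter). Compound 3 is estimated at 8000 nM, with an expected range from 2500 nM to 20000 nM.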

Compound 3, concentration for 50% growth inhibition: > 10000 nM
Compound 3 was reported as a limit (the forecaster's own chance of this, stated with the estimate: 45%); at least 1.2-fold (0.09 log units) between middle value and limit.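

In this assay compound 3 gives > 10000 nM, which is a limit of the assay and not a number. Exchanging chloro for 4-methylpiperazin-1-yl on this aromatic carbon, meta to a large group, gives an at least 1.0-fold higher number from compound 1 to compound 3 (0.02 log units; that floor lies within the scatter), so a group with a six-membered non-aromatic ring joins dimethylamino in yielding only a floor, and that floor does not show a real change. The step from dimethylamino to 4-methylpiperazin-1-yl cannot be read, as both ends are limits, and the anilides shown now sit mostly at one value: the limit of > 10000 nM in this assay, at which 2 of the 3 values shown sit.

For the compounds shown here, how far dimethylamino and 4-methylpiperazin-1-yl truly differ remains open, as does the true size of either exchange from chloro, with compound 1 the only exact value in this set. Also open, as far as these compounds go, is whether a primary amine or a carboxylic acid in the same place would give an exact value that could anchor a comparison at this position.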